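Series notes: ether replacement on the shared core

This account rests on a few compounds, and the source may have more. Where it says the series, first, only, none or still open, it means among the compounds named here.

Within the data shown here, compound 1 `COc1cc(OC)c(-c2coc3cc(OCC=C(C)C)ccc3c2=O)cc1OC` gives 3800 nM in a functional assay on HUVEC cells (Homo sapiens) for antiproliferative activity, read by MTT assay, with a stated time of 24 h (a lower number here means a stronger inhibitor, a higher number a weaker inhibitor), the lowest of the two numbers so far. Among the measured compounds shown here, compound 2 `COc1cc(OC)c(-c2coc3cc(OCc4ccccc4)ccc3c2=O)cc1OC` gives 9750 nM in this assay, and the step of a 2.6-fold higher number from compound 1 to compound 2 (0.41 log units; beyond the scatter) is the only measured change that bears on the new compound. Compound 3 `COc1cc(OC)c(-c2coc3cc(OCc4ccccc4C)ccc3c2=O)cc1OC` carries 2-methylphenyl in place of 2-methylprop-1-en-1-yl on a saturated chain carbon bound to an oxygen on an aromatic ring. Since the related change to the (2-methylbenzyl)oxy group already weakened compound 2 modestly, a similar weakening is expected for compound 3, a step of a 2.5-fold higher number from compound 1 to compound 3 (0.40 log units; beyond the scatter). The value for compound 3 in this assay is therefore estimated at 9500 nM, with a range of 4000 nM to 22000 nM.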

Compound 3, half-maximal inhibitory concentration: 4830 nM
Beside the measured number, compound 3's estimate is 2.0-fold (0.29 log units) above it, within the range that was stated.
By their numbers in this assay, from the lowest: compounds 1 and 3 (each within the scatter of the next); then compound 2.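

In this assay the (2-methylbenzyl)oxy group shows a 1.3-fold higher number from compound 1 to compound 3 (0.10 log units; within the scatter) against the (3-methylbut-2-en-1-yl)oxy group, so the loss seen with compound 2 does not hold for every aromatic replacement at this place. Methyl in place of hydrogen on an aromatic carbon gives a 2.0-fold lower number from compound 2 to compound 3 (0.31 log units; beyond the scatter) and is the only change separating those two compounds. No supporting evidence explains this methyl effect.

Open, going by these compounds, is whether a chlorine or methoxy group in place of that methyl would act alike. A longer chain or an amine at this place also remains untested in the compounds shown.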